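Furan-2-yl in Place of a Dimethylfuranyl Group

The source may report more compounds than this note shows. Statements on the series, on what has been measured and on what is new or still open speak of the compounds shown alone.

Measured so far:
compound 1 `CC1CCN(c2ccc(Nc3nccc(-c4ccco4)n3)cc2)CC1`: 1800 nM
compound 2 `CCN(CC)c1ccc(Nc2nccc(-c3cc(C)oc3C)n2)cc1`: only a limit, > 24000 nM

In a functional assay for inhibition, with Homo sapiens as the target (on this read-out higher numbers stand for weaker inhibition and lower numbers for stronger inhibition), compound 1 gives 1800 nM. Compound 2 stands at the limit of this assay, > 24000 nM, a limit and not a number, noted as the limit of > 24000 nM in this assay, at which 1 of the 2 values shown sits. Compound 3 `CCN(CC)c1ccc(Nc2nccc(-c3ccco3)n2)cc1` carries furan-2-yl in place of 2,5-dimethylfuran-3-yl on an aromatic carbon. Going by the values given here, no measured step joins the two compounds, so the size rests on expectation alone: a step from the limit toward stronger inhibition, clearly beyond the scatter, is expected, an at least 8.0-fold lower number from compound 2 to compound 3 (0.90 log units; beyond the scatter). Compound 3 is therefore estimated at 3000 nM, within 1000 nM to 12000 nM.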

Compound 3, half-maximal inhibitory concentration: 8700 nM
Estimate against measurement, compound 3: 2.9-fold (0.46 log units) below, within the range that was stated.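

In this assay, furan-2-yl in place of 2,5-dimethylfuran-3-yl gives an at least 2.7-fold lower number from compound 2 to compound 3 (0.44 log units; beyond the scatter), so this position responds to the change while the diethylamino group stays the same. Going by these compounds, the true size of that step stays open, because it starts from a limit: the limit of > 24000 nM in this assay, at which 1 of the 3 values shown sits. With furan-2-yl held constant, diethylamino in place of 4-methylpiperidin-1-yl gives a 4.8-fold higher number from compound 1 to compound 3 (0.68 log units; beyond the scatter), so the amine on the other side of the molecule also counts.

The compounds shown leave open how a furan carrying a single methyl group would read. They also leave open whether a thiophene here, or a morpholine in place of the amine, would keep the inhibition.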